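This account rests on a few compounds, and the source may have more. Where it says the series, first, only, none or still open, it means among the compounds named here.

Measured compounds in an ADME assay on microsomes from liver (Homo sapiens) for metabolic stability, read by LC-MS, using NADPH, with stated times of 10 min and 30 min; a lower number here means slower removal, a higher number faster removal of the compound:

- Compound 1 `CC[C@H]1c2cc(Cl)ccc2C(=O)N1c1cncc2c1CCC[C@H]2NC(C)=O`: compound 1 gives < 3.5 mL/min/kg, a limit of the assay and not a number.
- Compound 2 `CCC(=O)N[C@@H]1CCCc2c1cncc2N1C(=O)c2ccc(Cl)cc2[C@@H]1CC`: compound 2 gives < 3.5 mL/min/kg, likewise a limit.
- Compound 3 `CC1c2cc(Cl)ccc2C(=O)N1c1cccnc1`: compound 3 gives 12.2 mL/min/kg.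

Compound 1 therefore stands at the lower limit of this assay, and so does compound 2; compound 3 is the only one of the three with a read number, and it sits higher than that limit. The step that the two limits leave unreadable from compound 1 to compound 2 cannot be read in size, since both ends are limits (the limit of < 3.5 mL/min/kg in this assay, at which 2 of the 3 values shown sit).

The unmeasured compound 4 `CC(=O)N[C@@H]1CCCc2c1cncc2N1C(=O)c2ccc(Cl)cc2[C@@H]1C` differs from compound 1 by hydrogen in place of methyl on a saturated chain carbon bound to a saturated ring carbon. Within the data shown here, no measured step covers this change; the one step recorded, from compound 1 to compound 2, concerns another place and is unreadable anyway. Among the measured compounds shown here, compound 3 carries the methyl on the shared core but lacks the substituted saturated ring that compound 1 and compound 4 share, so its value shows only that a methyl-bearing core can be read above the limit; it gives no step. The expectation is that compound 4 stays close to compound 1, with an at least 1.1-fold higher number from compound 1 to compound 4 (0.05 log units; that floor lies within the scatter) as the estimated step, most likely again only a limit. The estimate for compound 4 in this assay is 4 mL/min/kg, with a range from 2.5 mL/min/kg to 10 mL/min/kg.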

Compound 4, clearance: < 3.5 mL/min/kg
Compound 4: a limit, no number; the forecaster's own chance of this, stated with the estimate: 55%; at least 1.1-fold (0.05 log units) between middle value and limit.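

Compound 1 and compound 4 both rest on a limit in this assay, not on a number, so no step between them can be read: the limit of < 3.5 mL/min/kg in this assay, at which 3 of the 4 values shown sit.

The compounds shown leave open where compound 1, compound 2 and compound 4 actually lie under that limit, and whether hydrogen in place of methyl at this place changes clearance at all.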